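The compounds below may be only part of what the source reports. "The series", "measured", "known", "first", "only" and "open" are said of these compounds alone.

Measured so far in an assay on cell membranes with adenosine receptor A1 (Rattus norvegicus) as the target; on this read-out lower numbers stand for stronger inhibition and higher numbers for weaker inhibition:
compound 1 `CCCn1cnc2c1c(=O)n(C)c(=O)n2CC(C)C` gives 13000 nM
compound 2 `C=CCn1cnc2c1c(=O)n(C)c(=O)n2CC(C)C` gives 13000 nM
compound 3 `CCCn1c(=O)c2c(ncn2CCC)n(CCC)c1=O` gives 2600 nM

Within the data shown here, the one change seen twice is vinyl in place of ethyl on a saturated chain carbon bound to an aromatic nitrogen. Between the two measured compounds it gave no change at the digits printed from compound 1 to compound 2 (within the scatter), so the substitution left the read-out where it was.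

Compound 3 carries a different core than compound 1; the difference between the two cores is not broken down here. Compound 3 sits lowest of the three numbers, and its gaps to compound 1 and compound 2 lie beyond the scatter.

Compound 4 `C=CCn1cnc2c1c(=O)n(CCC)c(=O)n2CCC` is unmeasured. It differs from compound 3 by vinyl in place of ethyl on a saturated chain carbon bound to an aromatic nitrogen, the same change as before, in the same place. Compound 4 is therefore expected to show no change at the digits printed from compound 3 to compound 4 (within the scatter), resting on the flat step no change at the digits printed from compound 1 to compound 2 (within the scatter), with the caveat that this rests on a single prior pair on another core. The estimate for compound 4 in this assay is 2600 nM, between 1000 nM and 7000 nM.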

Compound 4, inhibition constant: 1900 nM
For compound 4 the middle estimate is 1.4-fold (0.14 log units) above the measured one; the range from low to high includes it.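

Vinyl in place of ethyl on a saturated chain carbon bound to an aromatic nitrogen gives a 1.4-fold lower number from compound 3 to compound 4 (0.14 log units; within the scatter) in this assay. The flat result therefore carries from the core of compound 1 to the core of compound 3, and the two steps do not differ beyond the scatter: the same change on two cores in this assay, no change at the digits printed (within the scatter) from compound 1 to compound 2 and a 1.4-fold lower number (0.14 log units; within the scatter) from compound 3 to compound 4, 1.4-fold (0.14 log units) apart, within the scatter of two such steps. Among these compounds, this rests on only two pairs, with one change in one assay, so it does not show that the change would stay flat on any other core.

The compounds shown leave open whether a longer chain or a chain ending in an amine, in place of propyl or allyl, would also leave the read-out unchanged. They also leave open whether either core would respond alike to such groups.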